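Removing the para-chloro: expected cost in cytotoxicity

The compounds below may be only part of what the source reports. "The series", "measured", "known", "first", "only" and "open" are said of these compounds alone.

Measured compounds:
compound 1 `COc1ccc(/C=C2\N=C(c3ccc(C)cc3)N(C(=O)c3nc4c(c(C)nn4-c4ccccc4)c(=O)[nH]3)NC2=O)cc1`: 37.7 nM
compound 2 `COc1ccc(/C=C2\N=C(c3ccc(Cl)cc3)N(C(=O)c3nc4c(c(C)nn4-c4ccccc4)c(=O)[nH]3)NC2=O)cc1`: 12.9 nM

Compound 2 `COc1ccc(/C=C2\N=C(c3ccc(Cl)cc3)N(C(=O)c3nc4c(c(C)nn4-c4ccccc4)c(=O)[nH]3)NC2=O)cc1` holds the lowest number of the two measured in a functional assay on HCT-116 cells (Homo sapiens) for cytotoxicity, read by MTT assay, with a stated time of 48 h; a higher number here means a weaker inhibitor, a lower number a stronger inhibitor. Within the data shown here, its nearest neighbour is compound 1 `COc1ccc(/C=C2\N=C(c3ccc(C)cc3)N(C(=O)c3nc4c(c(C)nn4-c4ccccc4)c(=O)[nH]3)NC2=O)cc1`, which in this assay gives 37.7 nM, and the only measured step, a 2.9-fold lower number from compound 1 to compound 2 (0.47 log units; beyond the scatter), is a modest one beyond the scatter.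

Compound 3 `COc1ccc(/C=C2\N=C(c3ccccc3)N(C(=O)c3nc4c(c(C)nn4-c4ccccc4)c(=O)[nH]3)NC2=O)cc1` is the next member: the change is hydrogen in place of chloro on an aromatic carbon, so the 4-chlorophenyl of compound 2 becomes a plain phenyl. Among the measured compounds shown here, no measured step covers this exact change. For the measured compounds named here, the one step that bears on it, a 2.9-fold lower number from compound 1 to compound 2 (0.47 log units; beyond the scatter), shows that the chloro on this ring accompanies the lowest number seen, while a methyl there gives a higher one. Taking the chloro away altogether is therefore expected to move the number back up, by a step of roughly the size of that measured one, a 2.7-fold higher number from compound 2 to compound 3 (0.43 log units; beyond the scatter), though the direction is inferred rather than measured and a smaller move would not be surprising. Compound 3 is thus expected to give about 35 nM in this assay, within a range of 12 nM to 100 nM.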

Compound 3, half-maximal inhibitory concentration: 52.1 nM
Compound 3: middle estimate off by 1.5-fold (0.17 log units), on the low side; low and high end bracket the measured number.
By their numbers in this assay, from the lowest: compound 2; then compounds 1 and 3 (each within the scatter of the next).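

In this assay, the result shows that the chloro stands apart from a bare ring as well as from a methyl: a 4.0-fold higher number from compound 2 to compound 3 (0.61 log units; beyond the scatter), a step beyond the scatter in the 4-chlorophenyl to phenyl change. Hydrogen and methyl at this place, by contrast, cannot be told apart, since a 1.4-fold higher number from compound 1 to compound 3 (0.14 log units; within the scatter) lies within the scatter, so of the three groups only the chloro separates from the others, and compound 2 is the strongest of the three in this cell assay. Nothing in the available data accounts for this difference.

The compounds shown leave open whether the low number belongs to the chloro alone or would also appear with another halogen such as fluoro or bromo, or with a larger group such as trifluoromethyl or methoxy on the same aromatic carbon. They also leave open whether an amine or a carboxylic acid there would move the number in either direction, and whether the step seen with the chloro would keep its size on a different core.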